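The compounds below may be only part of what the source reports. "The series", "measured", "known", "first", "only" and "open" are said of these compounds alone.

Of the compounds shown here, three built on a shared core have been tested in an ADME assay on MT4 cells (Homo sapiens) for cytotoxicity, read by MTT assay, with a stated time of 5 days; on this read-out higher numbers stand for lower toxicity in this test and lower numbers for higher toxicity in this test. Compound 1 `N#Cc1ccccc1CN1C(=O)N(Cc2cccc(F)c2)S(=O)(=O)n2cccc21` gives > 305000 nM in this assay, which is a limit of the assay and not a number. Compound 3 `O=C1N(Cc2ccc(Cl)cc2Cl)c2cccn2S(=O)(=O)N1Cc1cccc(Br)c1` gives > 243000 nM in this assay, likewise a limit. Compound 2 `O=C1N(Cc2ccccc2Cl)c2cscc2S(=O)(=O)N1Cc1ccccc1`, the starting point of this account, gives > 119000 nM in this assay, again a limit rather than a measured number. All three values shown are therefore limits (the limit of > 119000 nM in this assay, at which 1 of the 3 values shown sits), (the limit of > 243000 nM in this assay, at which 1 of the 3 values shown sits), (the limit of > 305000 nM in this assay, at which 1 of the 3 values shown sits), none of the three yields a number in this assay, and compound 2 stands among them with nothing that sets it apart from the other two.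

Compound 4 `N#CCN1C(=O)N(Cc2ccccc2)S(=O)(=O)c2cscc21` differs from compound 2 by cyano in place of 2-chlorophenyl on a saturated chain carbon bound to an amide-type nitrogen in a ring. Among the compounds with values here, no step between two measured compounds has been reported, so there is no measured change to lean on. Because compound 2 itself returns only a limit > 119000 nM, the expected change for compound 4 in this assay is none beyond the scatter, and a further limit rather than a number is the most likely outcome. The step from compound 2 to compound 4 is thus estimated as a step that the limit leaves unreadable from compound 2 to compound 4. Compound 4 is expected to give about 200000 nM in this assay, within an estimated range from 50000 nM to 800000 nM.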

Compound 4, half-maximal cytotoxic concentration: 503000 nM
Compound 4: middle estimate off by 2.5-fold (0.40 log units), on the low side; the measured number falls inside the stated range.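

In this assay compound 4 gives 503000 nM, a measured number. Compound 2 gives > 119000 nM, which is a limit of the assay and not a number, so the step from compound 2 to compound 4 cannot be read. The compounds shown leave open whether cyano in place of 2-chlorophenyl changes the half-maximal cytotoxic concentration at all.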